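Compound 2 and its 4-methoxyphenyl counterpart, compound 3

The compounds below may be only part of what the source reports. "The series", "measured", "known", "first", "only" and "open" are said of these compounds alone.

Compound 1 `O=C1C(=Cc2ccc(Cl)cc2)C(=O)N(c2ccc(Cl)cc2)N1c1ccc(Cl)cc1`: 17300 nM
Compound 2 `COc1cc(C=C2C(=O)N(c3ccc(Cl)cc3)N(c3ccc(Cl)cc3)C2=O)ccc1O`: 7100 nM

Among the measured compounds shown here, in a functional assay on ECa-109 cells (Homo sapiens) for cytotoxicity, read by MTT assay, with a stated time of 72 h (on this read-out higher numbers stand for weaker inhibition and lower numbers for stronger inhibition), compound 2 gives 7100 nM, the lower of the two numbers measured so far. Compound 3 `COc1ccc(C=C2C(=O)N(c3ccc(Cl)cc3)N(c3ccc(Cl)cc3)C2=O)cc1` has the core of compound 2 but carries 4-methoxyphenyl in place of 4-hydroxy-3-methoxyphenyl on a double-bonded chain carbon bound to a double-bonded ring carbon. For the measured compounds named here, no measured step isolates this change. The only one bearing on it, a 2.4-fold lower number from compound 1 to compound 2 (0.39 log units; beyond the scatter), is modest and brought in the 4-hydroxy-3-methoxyphenyl group in place of 4-chlorophenyl at that same place, so a step of similar or smaller size toward a higher number is expected in this assay. The expected step is a 1.5-fold higher number from compound 2 to compound 3 (0.19 log units; within the scatter). Compound 3 is estimated at 11000 nM, with an expected range of 5000 nM to 24000 nM.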

Compound 3, half-maximal inhibitory concentration: > 128000 nM
Compound 3: no number, only a limit; the forecaster's own chance of this, stated with the estimate: 3%; middle value at least 11-fold (1.06 log units) from the limit.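

Among the compounds shown here, compound 3 gives no number in this assay, only a limit: the limit of > 128000 nM in this assay, at which 1 of the 3 values shown sits. Even so, an at least 18-fold higher number from compound 2 to compound 3 (1.25 log units; beyond the scatter) is a large step, while the earlier 2.4-fold lower number from compound 1 to compound 2 (0.39 log units; beyond the scatter) was only modest, so the group on the double-bonded chain carbon bound to a double-bonded ring carbon can move this read-out much further than the earlier compounds showed. The second new step, an at least 7.3-fold higher number from compound 1 to compound 3 (0.86 log units; beyond the scatter), shows that 4-methoxyphenyl here also falls short of the 4-chlorophenyl of compound 1, which places compound 1 between compound 2 and compound 3.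

As far as these compounds go, how far the true number of compound 3 lies past the limit stays open. So does whether the hydroxy group of compound 2 alone accounts for the step, as a 4-hydroxyphenyl or a 4-aminophenyl group at this place could show.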